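The source may report more compounds than this note shows. Statements on the series, on what has been measured and on what is new or still open speak of the compounds shown alone.

Compound 1 `CC1=C(/C=C/C(=O)/C=C/c2cccc(C(F)(F)F)c2)C(C)(C)CCC1` and compound 2 `CC1=C(/C=C/C(=O)/C=C/c2cc(C(F)(F)F)cc(C(F)(F)F)c2)C(C)(C)CCC1` share one core and differ only on the aromatic ring. In a functional assay on PC-3 cells (Homo sapiens) for cytotoxicity, read by MTT assay, with a stated time of 72 h (a lower number here means a stronger inhibitor, a higher number a weaker inhibitor), compound 1 gives 7700 nM, and compound 2 gives 7200 nM. The change between them is trifluoromethyl in place of hydrogen on an aromatic carbon, and it produced a 1.1-fold lower number from compound 1 to compound 2 (0.03 log units; within the scatter). Compound 3 `CC1=C(/C=C/C(=O)/C=C/c2ccccc2)C(C)(C)CCC1O` has a core that differs from that of compound 1; how the two cores differ is not broken down here. In this assay compound 3 gives 15500 nM, the highest of the three numbers. Compound 4 `CC1=C(/C=C/C(=O)/C=C/c2ccc(C(F)(F)F)cc2)C(C)(C)CCC1O` has not yet been measured; it differs from compound 3 by trifluoromethyl in place of hydrogen on an aromatic carbon. This is the same kind of change as that from compound 1 to compound 2, though the place differs: in compound 2 the entering group sits meta to a large group and meta to a trifluoromethyl group, in compound 4 it sits para to a large group. The step of a 1.3-fold lower number from compound 3 to compound 4 (0.11 log units; within the scatter) is expected to be small, because the same kind of change gave a 1.1-fold lower number from compound 1 to compound 2 (0.03 log units; within the scatter). For compound 4 the estimated value in this assay is 12000 nM, within a range of 5000 nM to 30000 nM.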

Compound 4, half-maximal inhibitory concentration: 10200 nM
Compound 4: the middle estimate sits 1.2-fold (0.07 log units) above what was measured; low and high end bracket the measured number.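

In this assay, trifluoromethyl in place of hydrogen on an aromatic carbon gave a 1.5-fold lower number from compound 3 to compound 4 (0.18 log units; within the scatter). Set beside the earlier case, the change behaves alike on the two cores, with no gap between the steps that can be told from scatter: the same change on two cores in this assay, a 1.1-fold lower number (0.03 log units; within the scatter) from compound 1 to compound 2 and a 1.5-fold lower number (0.18 log units; within the scatter) from compound 3 to compound 4, 1.4-fold (0.15 log units) apart, within the scatter of two such steps Both steps lie within the scatter, so neither shows that the change moves the number at all, and two pairs, with the entering group at different places on the ring, do not establish how it would behave on other cores in this series.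

The compounds shown leave open whether another group on the same aromatic carbon, such as an amine, a carboxylic acid or a nitrile, would give a step beyond the scatter. They also leave open what trifluoromethyl would do on the core of compound 1 when it sits para to a large group, as it does in compound 4.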